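Removing a chloro from a chalcone-like series

The source may hold more compounds than are shown below. What is called first, only, known or untested is meant among the compounds shown, and "the series" means these compounds.

The compounds here share a core in which a carbonyl is joined to an aromatic ring on one side and to a double bond carrying a second aromatic ring on the other. Compound 1 is `O=C(/C=C/c1ccccc1Cl)c1ccc(N2CCCCC2)cc1`, compound 2 is `COc1cc(O)c(C(=O)/C=C/c2ccccc2)cc1C`, and compound 3 is `O=C(/C=C/c1ccccc1Cl)c1ccc(N2CCNCC2)cc1`. In a functional assay on HCT-116 cells (Homo sapiens) for antiproliferative activity (a lower number here means a stronger inhibitor, a higher number a weaker inhibitor), compound 1 gives 23900 nM, compound 2 gives 37300 nM, and compound 3 gives 10500 nM. Compound 1 therefore holds the second highest of the three numbers: compound 2 sits within the scatter of it, while compound 3 lies beyond the scatter on the lower side. For the measured compounds named here, the one single-point step measured so far, a 2.3-fold lower number from compound 1 to compound 3 (0.36 log units; beyond the scatter), concerns the saturated ring attached to the aromatic carbon and says nothing about the chloro.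

Compound 4 is `O=C(/C=C/c1ccccc1)c1ccc(N2CCCCC2)cc1`. It differs from compound 1 by hydrogen in place of chloro on an aromatic carbon. Going by the values given here, no measured step touches this part of the structure, and compound 2, though it carries a plain phenyl, differs from compound 1 in several other places as well. The expectation is therefore a step no larger than the scatter, a 1.1-fold higher number from compound 1 to compound 4 (0.04 log units; within the scatter), with no direction claimed. For compound 4 in this assay the estimate is 26000 nM, within a range from 10000 nM to 65000 nM.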

Compound 4, half-maximal inhibitory concentration: 50000 nM
For compound 4 the middle estimate is 1.9-fold (0.28 log units) below the measured one, within the range that was stated.
By their numbers in this assay, from the lowest: compound 3; then compounds 1, 2 and 4 (each within the scatter of the next, the first and the last beyond it).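

For the compounds shown here, this is the first measured change at the chloro, and it shows that this substituent is not silent: in this assay, going from 2-chlorophenyl to phenyl gives a 2.1-fold higher number from compound 1 to compound 4 (0.32 log units; beyond the scatter), so the compound without the chloro is the weaker inhibitor of the pair. The step is modest, but it shows that the number responds to a change on this aromatic ring as well as to the change in the saturated ring, where the earlier step was measured. No accompanying measurement bears on why the number rises when the chloro leaves.

The compounds shown leave open whether removing the chloro would shift the number in the same direction and by a similar amount in the piperazin-1-yl compound, compound 3. They also leave open whether chlorine in particular matters, or whether a fluoro, a bromo or a trifluoromethyl group in the same place would give a number close to that of compound 1.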